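The source may report more compounds than this note shows. Statements on the series, on what has been measured and on what is new or still open speak of the compounds shown alone.

Two urea-linked compounds sharing one core have been tested in a functional assay on A549 cells (Homo sapiens) for inhibition, read by sulforhodamine B assay, with a stated time of 48 h, tested at 100 uM; a lower number here means a stronger effect, a higher number a weaker effect of the compound at the concentration tested. Compound 1 `COc1cc(Cl)cc(-c2nn(-c3cccc(NC(=O)Nc4cc(C(F)(F)F)cc(C(F)(F)F)c4)c3)cc2-c2ccncc2)c1` gives -68% in this assay, while compound 2 `COc1cc(Cl)cc(-c2nn(-c3cccc(NC(=O)Nc4ccc(Cl)c(Cl)c4)c3)cc2-c2ccncc2)c1` gives -10%. Of the two numbers shown, compound 2 stands highest, and its nearest neighbour, compound 1, lies a good way lower, beyond the usual scatter. The not yet measured compound 3 `COc1cc(Cl)cc(-c2nn(-c3cccc(NC(=O)Nc4cccc(C(F)(F)F)c4)c3)cc2-c2ccncc2)c1` departs from compound 2 by one change: 3-(trifluoromethyl)phenyl in place of 3,4-dichlorophenyl on an amide-type nitrogen. Among the compounds with values here, no step between measured compounds describes exactly this exchange, so the only guide is that compound 1, whose aryl ring carries two trifluoromethyl groups, gives -68%. From this, a step toward a lower number is expected, and compound 3 is estimated to reach -35% in this assay, within a range from -75% to 5%. The step from compound 2 to compound 3 is expected to be about a number 25 percentage points lower from compound 2 to compound 3 (beyond the scatter), larger than the scatter but uncertain in size.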

Compound 3, a percentage reported as activity, at one concentration (the size of the read-out at that concentration, not a potency): -24%
Beside the measured number, compound 3's estimate is 11 percentage points below it; the measured number falls inside the stated range.
By their numbers in this assay, from the lowest: compound 1; then compound 3; then compound 2.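

In this assay the exchange of 3,4-dichlorophenyl for 3-(trifluoromethyl)phenyl on the amide-type nitrogen gives a number 14 percentage points lower from compound 2 to compound 3 (beyond the scatter) and so a modest gain in effect at this position. Hydrogen in place of trifluoromethyl on an aromatic carbon gives a number 44 percentage points higher from compound 1 to compound 3 (beyond the scatter) as a large step, so among these compounds the ring with a single trifluoromethyl group stays well short of the ring with two. No measurement shown here accounts for either step.

The compounds shown leave open how this aryl ring would respond to other groups, such as a nitrile, a methoxy group or an amine, and what would follow if the urea were replaced by a simple amide. With a read-out at one concentration only, these steps speak of a stronger or weaker effect at that concentration and leave open how the compounds would compare at any other.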